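The compounds below may be only part of what the source reports. "The series", "measured", "known", "first", "only" and "open" are said of these compounds alone.

In a functional assay on MCF7 cells (Homo sapiens) for inhibition, read by colorimetric assay and MTT assay, with a stated time of 72 h (on this read-out higher numbers stand for weaker inhibition and lower numbers for stronger inhibition), compound 1 (`Cn1c2cnc1OCCCCCCCCOc1cc(F)ccc1-2`) gives 35000 nM, compound 2 (`C=CCCCCOc1ccccc1-c1cnc(OCCCCC=C)n1C`) gives 5000 nM and compound 3 (`C=CCCCCCOc1ncc(-c2ccccc2OCCCCC=C)n1C`) gives 63000 nM. Compound 3 therefore lies within the scatter of compound 1 and well clear of compound 2. The next structure is compound 4 (`C=CCCCCOc1ccccc1-c1cnc(OC)n1C`), and the change to it is hydrogen in place of hex-5-en-1-yl on a saturated chain carbon bound to an oxygen on an aromatic ring. Cut one bond further out, this reads hept-6-en-1-yl to methyl.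

Going by the values given here, one measured step bears on this chain: a 13-fold higher number from compound 2 to compound 3 (1.10 log units; beyond the scatter), a large step with allyl in place of vinyl. Read in reverse, it pairs a shorter chain with a lower number. Among the compounds with values here, it is a single step, however, and no measured compound carries a short group at this place. The trend cannot be safely extended to methyl. A moderate move towards a lower number in this assay is expected, smaller than the measured step and held with low confidence. The expected step is a 2.5-fold lower number from compound 3 to compound 4 (0.40 log units; beyond the scatter). For compound 4 the estimated value is 25000 nM, with an expected range from 7000 nM to 90000 nM.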

Compound 4, half-maximal inhibitory concentration: 98000 nM
For compound 4 the middle estimate is 3.9-fold (0.59 log units) below the measured one, and the stated range ends below it.
By their numbers in this assay, from the lowest: compound 2; then compounds 1, 3 and 4 (each within the scatter of the next, the first and the last beyond it).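

In this assay, methoxy in compound 4 and (hept-6-en-1-yl)oxy in compound 3 cannot be told apart at this place: a 1.6-fold higher number from compound 3 to compound 4 (0.19 log units; within the scatter). Set against the (hex-5-en-1-yl)oxy group of compound 2, the same short group gives a 20-fold higher number from compound 2 to compound 4 (1.29 log units; beyond the scatter), a step that shows the lower number does not simply follow a shorter chain, with compound 4 going against that reading; among these three compounds, only compound 2 stands clear of the others. No measured evidence is available here to account for this behaviour at the chain.

Still open, from the compounds shown here alone, is whether the lower number of compound 2 is confined to hex-5-en-1-yl or extends to nearby chains such as pent-4-en-1-yl, and whether it depends on the terminal double bond, a question a saturated hexyl chain would address. Also open is how this place responds to a chain ending in an amine or a carboxylic acid, since every group shown here is either methyl or an unbranched alkenyl chain.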